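Working notes: from compound 3 to compound 4

The source may report more compounds than this note shows. Statements on the series, on what has been measured and on what is new or still open speak of the compounds shown alone.

Values in a toxicity assay on L02 cells (Homo sapiens) for cytotoxicity, read by MTT assay, with a stated time of 72 h (on this read-out higher numbers stand for weaker inhibition and lower numbers for stronger inhibition), so far
- compound 1 `CN(C)CCCCCn1c2c(c3ccccc31)C(=O)c1c[n+]([O-])c3ccccc3c1C2=O` gives 240 nM
- compound 2 `O=C1c2c[n+]([O-])c3ccccc3c2C(=O)c2c1c1ccccc1n2Cc1cn([C@H]2O[C@H](CO)[C@@H](O)[C@H]2O)nn1` gives 950 nM
- compound 3 `CC1(C)OCC(Cn2cc(Cn3c4c(c5ccccc53)C(=O)c3c[n+]([O-])c5ccccc5c3C4=O)nn2)O1` gives 120 nM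

Compound 3 at 120 nM and compound 1 at 240 nM lie within the scatter of each other. Next is compound 4 `O=C1c2c[n+]([O-])c3ccccc3c2C(=O)c2c1c1ccccc1n2Cc1cn(CC(O)CO)nn1` with the change (1,2-dihydroxyethyl in place of 2,2-dimethyl-1,3-dioxolan-4-yl on a saturated chain carbon bound to an aromatic nitrogen), which is 1,2-dihydroxyethyl in place of 2,2-dimethyl-1,3-dioxolan-4-yl on a saturated chain carbon bound to an aromatic nitrogen. Among the compounds with values here, the one measured step bearing on this is a 7.9-fold lower number from compound 2 to compound 3 (0.90 log units; beyond the scatter), where a 3,4-dihydroxy-5-(hydroxymethyl)oxolan-2-yl group gave way to (2,2-dimethyl-1,3-dioxolan-4-yl)methyl. Compound 4 has free hydroxyl groups again, so part of that step should reverse in this assay as a higher number. Expected is a 3.3-fold higher number from compound 3 to compound 4 (0.52 log units; beyond the scatter), smaller than the measured step. The estimate for compound 4 is 400 nM, with a range of 150 nM to 1000 nM.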

Compound 4, half-maximal inhibitory concentration: 1070 nM
Beside the measured number, compound 4's estimate is 2.7-fold (0.43 log units) below it; the measured number lies above the stated range.
By their numbers in this assay, from the lowest: compounds 3 and 1 (each within the scatter of the next); then compounds 2 and 4 (each within the scatter of the next).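

In this assay, 1,2-dihydroxyethyl in place of 2,2-dimethyl-1,3-dioxolan-4-yl on this saturated chain carbon gives an 8.9-fold higher number from compound 3 to compound 4 (0.95 log units; beyond the scatter), so unmasking the diol alone produces a step beyond the scatter. With a 1.1-fold higher number from compound 2 to compound 4 (0.05 log units; within the scatter), the 2,3-dihydroxypropyl and 3,4-dihydroxy-5-(hydroxymethyl)oxolan-2-yl groups stand within the scatter of each other. The 4-(dimethylamino)butyl chain also gives a lower number, seen as a 4.5-fold higher number from compound 1 to compound 4 (0.65 log units; beyond the scatter).

From the compounds shown here alone, whether a methoxy ether or a carboxylic acid here would read like the diol or like the 2,2-dimethyl-1,3-dioxolan-4-yl group remains open. Nothing on hand explains these steps.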